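Same Change, Two Cores: Hydrogen in Place of a Group

The source may hold more compounds than are shown below. What is called first, only, known or untested is meant among the compounds shown, and "the series" means these compounds.

Compound 1 `CC(C)(C)[Si](C)(C)O[C@@H]1CCCO[C@@H]1/C=C/C(=O)OCc1ccccc1` and compound 3 `CC(C)(C)[Si](C)(C)O[C@@H]1CCCO[C@@H]1CC(=O)OCc1ccccc1` share much of their skeleton, but the difference between the two cores is not broken down here. In a functional assay on SW1573 cells (Homo sapiens) for antiproliferative activity, read by sulforhodamine B assay, with a stated time of 48 h (on this read-out lower numbers stand for stronger inhibition of growth and higher numbers for weaker inhibition of growth), compound 1 gives 37000 nM. Compound 3 gives 30000 nM in this assay, a number that lies within the usual scatter of the number for compound 1, so the two are treated as alike.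

Compound 2 `O=C(/C=C/[C@H]1OCCC[C@H]1O)OCc1ccccc1` differs from compound 1 in one place: a hydrogen atom in place of a group of 7 heavy atoms (6 carbon, 1 silicon; no ring), on an oxygen on a saturated carbon. For compound 2, this assay reports only a limit of the assay, > 100000 nM. The change therefore brought an at least 2.7-fold higher number from compound 1 to compound 2 (0.43 log units; beyond the scatter). Among the three measured values, one sits at the limit of > 100000 nM in this assay, at which 1 of the 3 values shown sits, which is why the size of this step is known only as a lower bound.

Compound 4 `O=C(C[C@H]1OCCC[C@H]1O)OCc1ccccc1` is not yet measured. It stands to compound 3 exactly as compound 2 stands to compound 1: a hydrogen atom in place of a group of 7 heavy atoms (6 carbon, 1 silicon; no ring), on an oxygen on a saturated carbon. The place of the change is the same, word for word, in both pairs, so this is the same change made on a second core.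

On that basis compound 4 is expected to show a step of a 3.7-fold higher number from compound 3 to compound 4 (0.56 log units; beyond the scatter) in this assay, resting on the measured step of an at least 2.7-fold higher number from compound 1 to compound 2 (0.43 log units; beyond the scatter) and on the starting number of compound 3, 30000 nM. Compound 4 is therefore estimated at 110000 nM in this assay. The expected range for compound 4 runs from 50000 nM to 300000 nM, and it is quite possible that this assay will again report only a limit rather than a number for compound 4.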

Compound 4, concentration for 50% growth inhibition: > 100000 nM
Compound 4 ended at the assay's limit; the forecaster's own chance of this, stated with the estimate: 65%; the middle value is on the limit's open side.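

In this assay, a hydrogen atom in place of the group of 7 heavy atoms (6 carbon, 1 silicon; no ring), on an oxygen on a saturated carbon, brought an at least 3.3-fold higher number from compound 3 to compound 4 (0.52 log units; beyond the scatter), so on the second core the change again moved the number upward and beyond the scatter. The two steps point the same way, but each is known only as a lower bound, so this pair of cores shows that the direction carries over and does not show how large either step is or whether the core alters it: the same change on two cores in this assay, an at least 2.7-fold higher number (0.43 log units; beyond the scatter) from compound 1 to compound 2 and an at least 3.3-fold higher number (0.52 log units; beyond the scatter) from compound 3 to compound 4; the limit leaves it open whether they differ Neither compound that carries the hydrogen gives a number, only a limit of the assay, so the effect of the change cannot be sized on either core: the limit of > 100000 nM in this assay, at which 2 of the 4 values shown sit.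

The compounds shown leave open what a group of intermediate size on that oxygen would do, such as a methyl ether, an acetate or a trimethylsilyl group, any of which might give a readable number in place of a limit. They also leave open whether the same step would hold if the benzyl ester were replaced by a carboxylic acid or an amide.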